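A second chloro group on compound 3

This account rests on a few compounds, and the source may have more. Where it says the series, first, only, none or still open, it means among the compounds named here.

On the shared core, compound 1 `CN(C)Cc1cc(C(=O)/C=C/c2ccccc2Cl)cc(CN(C)C)c1O` carries a 2-chlorophenyl group, compound 2 `CN(C)Cc1cc(C(=O)/C=C/c2cccc(Cl)c2)cc(CN(C)C)c1O` a 3-chlorophenyl group and compound 3 `CN(C)Cc1cc(C(=O)/C=C/c2ccc(Cl)cc2)cc(CN(C)C)c1O` a 4-chlorophenyl group. In a functional assay on cells (Tumor Cell line, Homo sapiens) for cytotoxicity (on this read-out higher numbers stand for weaker inhibition and lower numbers for stronger inhibition), compound 3 gives 10000 nM and compound 1 gives 9550 nM, two values within the scatter of each other, while compound 2 gives 4680 nM.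

Compound 4 `CN(C)Cc1cc(C(=O)/C=C/c2ccc(Cl)c(Cl)c2)cc(CN(C)C)c1O` turns the 4-chlorophenyl group of compound 3 into a 3,4-dichlorophenyl group: chloro in place of hydrogen on an aromatic carbon. Among the compounds with values here, no measured step adds a chloro group, so the evidence is indirect. Within the data shown here, two steps bear on it: a 2.0-fold lower number from compound 1 to compound 2 (0.31 log units; beyond the scatter), and a 2.1-fold higher number from compound 2 to compound 3 (0.33 log units; beyond the scatter). Both are modest and favour the 3-chlorophenyl group, whereas a 1.0-fold higher number from compound 1 to compound 3 (0.02 log units; within the scatter) shows no real difference.

Compound 4 keeps the 4-chloro pattern and also gains the 3-chloro pattern, so a small downward step of about that size is expected in this assay, though this is uncertain. The expected step is a 2.0-fold lower number from compound 3 to compound 4 (0.30 log units; within the scatter). For compound 4 the estimate is 5000 nM, with an expected range from 2000 nM to 11000 nM.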

Compound 4, half-maximal inhibitory concentration: 2350 nM
Compound 4: the middle estimate sits 2.1-fold (0.33 log units) above what was measured; the range from low to high includes it.
By their numbers in this assay, from the lowest: compounds 4 and 2 (each within the scatter of the next); then compounds 1 and 3 (each within the scatter of the next).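

In this assay, within the data shown here, adding a chloro group to the ring of compound 3 gives a 4.3-fold lower number from compound 3 to compound 4 (0.63 log units; beyond the scatter) and so gives the first direct reading of a second chloro group on this ring. Adding a chloro group to the ring of compound 2 gives a 2.0-fold lower number from compound 2 to compound 4 (0.30 log units; within the scatter) and so leaves the two compounds within the scatter of each other. With the change from a 2-chlorophenyl to a 3,4-dichlorophenyl group, there is a 4.1-fold lower number from compound 1 to compound 4 (0.61 log units; beyond the scatter) and this fits a pattern among these four compounds: the two carrying a chloro group at the 3 position have the lower numbers.

No measurement shown here explains why the 3,4-dichlorophenyl group gives this result. Going by these compounds, it remains open whether a methoxy group or a fluoro group on the same aromatic carbon would give a similar number.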